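Trifluoromethoxy for trifluoromethyl in a quinoline urea series

A few compounds are considered here, and "the series" means these few. Any claim that something is new, unique, unknown or untested is made for them only; others in the source may bear on it.

Compound 1 `COc1ccc(NC(=O)Nc2cc(C)nc3ccccc23)cc1`: 787 10^-6 cm/s
Compound 2 `Cc1cc(NC(=O)Nc2ccccc2C(F)(F)F)c2ccccc2n1`: 945 10^-6 cm/s
Compound 3 `CSc1ccc(NC(=O)Nc2cc(C)nc3ccccc23)cc1`: 473 10^-6 cm/s

In an ADME assay for permeability, using PAMPA, at pH 7.4 (on this read-out lower numbers stand for lower permeability and higher numbers for higher permeability), compound 2 gives the highest of the three numbers, with compound 1 nearest at a gap within the scatter and compound 3 furthest, also within the scatter. Compound 4 `Cc1cc(NC(=O)Nc2ccccc2OC(F)(F)F)c2ccccc2n1` differs from compound 2 in one place: trifluoromethoxy in place of trifluoromethyl on an aromatic carbon. Among the measured compounds shown here, the only measured single step, a 1.7-fold lower number from compound 1 to compound 3 (0.22 log units; within the scatter), concerns an exchange of a small group on the same aromatic carbon position of the other aryl ring and stayed within the scatter; it is the only step that bears on the change here, and it points to no movement beyond the scatter. For the measured compounds named here, no measured pair shows trifluoromethoxy against trifluoromethyl, so the expectation rests on compound 2 alone. Compound 4 is therefore expected to give 850 10^-6 cm/s in this assay, with a range from 500 10^-6 cm/s to 1400 10^-6 cm/s. This means an expected step of a 1.1-fold lower number from compound 2 to compound 4 (0.05 log units; within the scatter), a change not beyond the scatter.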

Compound 4, apparent permeability: 1110 10^-6 cm/s
For compound 4 the middle estimate is 1.3-fold (0.12 log units) below the measured one, within the range that was stated.
By their numbers in this assay, from the lowest: compounds 3, 1, 2 and 4 (each within the scatter of the next, the first and the last beyond it).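

In this assay, among the compounds shown here, trifluoromethoxy in place of trifluoromethyl gives a 1.2-fold higher number from compound 2 to compound 4 (0.07 log units; within the scatter) and stays within the scatter; this is the first measured change on this aromatic carbon, ortho to a large group. At this place, in this one pair, the added oxygen and the hydrogen-bond acceptor counted with it come with no movement beyond the scatter. Nothing shown gives a reason for this result.

The compounds shown leave open whether a different kind of group on this aromatic carbon, such as an amine, a carboxylic acid or a longer chain like butoxy, would move the number beyond the scatter. They also leave open whether the same exchange would behave alike at another place on this ring or on another core.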